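Swapping the amide aryl for a short alkyl chain

A few compounds are considered here, and "the series" means these few. Any claim that something is new, unique, unknown or untested is made for them only; others in the source may bear on it.

Measured compounds:
compound 1 `Cc1cccc(Cn2c(CN3CCN(C(=O)c4cccnc4)CC3)nc3ccccc32)c1` gives 24.5% in an assay on isolated protein for inhibition of aldehyde dehydrogenase 1A1 (Homo sapiens), read by spectrophotometry, tested at 10 uM; on this read-out lower numbers stand for less inhibition and higher numbers for more inhibition at the one concentration tested (going by the name of the read-out)
compound 2 `COc1ccc(C(=O)N2CCN(Cc3nc4ccccc4n3Cc3cccc(C)c3)CC2)cc1` gives 55.5% in this assay

Among the measured compounds shown here, compound 2 holds the higher of the two numbers so far. For the measured compounds named here, compound 1 sits below it, and the one step computed, a number 31 percentage points higher from compound 1 to compound 2 (beyond the scatter), shows that what is attached to the carbonyl carbon in this shared core is a place where the read-out moves well beyond the scatter.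

Compound 3 `CCCC(=O)N1CCN(Cc2nc3ccccc3n2Cc2cccc(C)c2)CC1` has not yet been measured. It differs from compound 2 in exactly that place: propyl in place of 4-methoxyphenyl on a carbonyl carbon. Going by the values given here, the one measured step bears on compound 3 only in so far as it marks the carbonyl substituent as a sensitive position; no measured pair shows what a propyl does there, so the direction of the change is not fixed by the data. Among the compounds with values here, the only evidence is that the group giving the high number in compound 2 is being removed. For compound 3 a step downward in this assay is therefore expected, estimated as a number 20.5 percentage points lower from compound 2 to compound 3 (beyond the scatter), though with wide uncertainty.

Compound 3 is therefore estimated at 35% in this assay, within a range from 10% to 62%.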

Compound 3, a percentage reported as inhibition, at one concentration (the size of the read-out at that concentration, not a potency): 79.1%
The estimate for compound 3 lay 44.1 percentage points below the measured number, outside the stated range (above it).
By their numbers in this assay, from the lowest: compound 1; then compound 2; then compound 3.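

In this assay the change from 4-methoxyphenyl to propyl on the carbonyl carbon gives a number 23.6 percentage points higher from compound 2 to compound 3 (beyond the scatter) and so shows that an aromatic ring at this position is not needed for a high number, since the propyl has no ring and compound 3 stands highest of the three. The change from pyridin-3-yl to propyl gives a number 54.6 percentage points higher from compound 1 to compound 3 (beyond the scatter) and places both aryl groups shown below the short alkyl chain, with pyridin-3-yl lowest, 4-methoxyphenyl in the middle and propyl highest, each gap beyond the scatter. Nothing given here accounts for this order, which therefore stands as an observation on three compounds only.

As far as these compounds go, it remains open whether the number would rise further, hold or fall with a longer chain such as pentyl, a cyclohexyl ring, or a chain ending in an amine or a carboxylic acid on the same carbonyl carbon. All three numbers come from one concentration, so they leave open how the potencies of these compounds compare and whether the same order would hold if another part of the shared core were changed.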